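The source may hold more compounds than are shown below. What is called first, only, known or untested is meant among the compounds shown, and "the series" means these compounds.

Within the data shown here, in an ADME assay on CHO cells (Cricetulus griseus) for cytotoxicity, read by MTT assay, with a stated time of 24 h (a lower number here means that less compound is tolerated, a higher number that more compound is tolerated), compound 3 (`CC1Cn2c(nc([N+](=O)[O-])c2-c2ccc(C=O)cc2)O1`) gives 255000 nM as the only exact number so far. Compound 1 (`CC1Cn2c(nc([N+](=O)[O-])c2-c2ccc(CO)cc2)O1`) reads > 500000 nM as a limit of the assay. Compound 2 (`CCCOc1ccc(-c2c([N+](=O)[O-])nc3n2CC(C)O3)cc1`) reads > 125000 nM as a limit too. Compound 4 (`CC1Cn2c(nc([N+](=O)[O-])c2-c2ccc(OC(F)(F)F)cc2)O1`) carries trifluoromethoxy in place of formyl on an aromatic carbon, para to a large group (trifluoromethoxy in place of formyl on an aromatic carbon). Among the measured compounds shown here, no measured step involves trifluoromethoxy. For the measured compounds named here, the only step with a readable size is (an at least 1.9-fold lower number from compound 1 to compound 3 (0.29 log units; that floor lies within the scatter)), while the others (a step that the two limits leave unreadable from compound 1 to compound 2; a step that the limit leaves unreadable from compound 2 to compound 3) give no size. On that slim basis, this assay is expected to show no step beyond the scatter, in either direction (a 1.4-fold lower number from compound 3 to compound 4 (0.15 log units; within the scatter)). For compound 4 the estimate is 180000 nM in an expected range from 70000 nM to 450000 nM for now.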

Compound 4, half-maximal cytotoxic concentration: > 125000 nM
Compound 4: a limit, no number; the forecaster's own chance of this, stated with the estimate: 50%; the middle value lies beyond the limit too.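

In this assay compound 4 gives > 125000 nM, a limit and not a number. Among these compounds, no step linking compound 4 with compound 1, compound 2 or compound 3 can be read. The compounds shown leave open whether changing this group moves tolerance beyond the scatter.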